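The compounds below may be only part of what the source reports. "The series", "measured", "known", "first", "only" and "open" are said of these compounds alone.

Measured in a physicochemical assay for lipophilicity, at pH 7.4; on this read-out lower numbers stand for lower lipophilicity and higher numbers for higher lipophilicity:
Compound 1 `CN(Cc1ccc2nccn2c1)c1nnc(-c2ccc(OC3CCCC3)cc2)o1`: 4.1
Compound 2 `CNC(=O)c1sc(N2CC3CC2(CNC(=O)c2c[nH]c4ncc(C(F)(F)F)cc24)C3)nc1C(F)(F)F`: 4.2

In this assay, compound 2 gives 4.2 and compound 1 gives 4.1, so the two stand within the usual scatter of each other. Compound 3 `CNC(=O)c1sc(N2CC3CC2(CNC(=O)c2c[nH]c4ncc(C)cc24)C3)nc1C(F)(F)F` has not yet been measured. It differs from compound 2 in one place, with methyl in place of trifluoromethyl on an aromatic carbon. For the measured compounds named here, no measured pair shows this change, so what follows is a judgement and not a reading. The expected change is a fall beyond the scatter, a number 0.60 log units lower from compound 2 to compound 3 (beyond the scatter). For compound 3 the estimate is 3.6, with an expected range from 3.2 to 4.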

Compound 3, distribution coefficient: 3.5
Estimate against measurement, compound 3: 0.10 log units above; measured number inside the range.
By their numbers in this assay, from the lowest: compound 3; then compounds 1 and 2 (each within the scatter of the next).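

Swapping the group on this aromatic carbon for methyl in place of trifluoromethyl gives the first step here that can be read at a single place: in this assay the number falls, a number 0.70 log units lower from compound 2 to compound 3 (beyond the scatter), with the rest of the structure unchanged. The read-out of this assay therefore responds to what sits at this position, something compound 1 and compound 2, which differ in more than one place, could not show.

Where a chlorine atom, a methoxy group or an amine would fall on this scale remains open, as does whether the same swap elsewhere gives a similar step. No measurement at hand gives a cause for the size of this step.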